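The source may report more compounds than this note shows. Statements on the series, on what has been measured and on what is new or still open speak of the compounds shown alone.

Compound 3 `COc1ccc(/C=C(/SCc2ccc(F)cc2)C(=O)c2ccc(C(=O)O)cc2)cc1O` gives 10000 nM in a functional assay on DU-145 cells (Homo sapiens) for inhibition, read by trypan blue exclusion, with a stated time of 96 h (a higher number here means a weaker inhibitor of growth, a lower number a stronger inhibitor of growth), and stands as the highest of the three numbers measured. Compound 1 `O=C(O)c1ccc(C(=O)/C(=C\c2ccc(F)c([N+](=O)[O-])c2)SCc2ccc(F)cc2)cc1` gives 1000 nM in this assay, and compound 2 `O=C(O)c1ccc(C(=O)/C(=C\c2ccc(Br)c([N+](=O)[O-])c2)SCc2ccc(Br)cc2)cc1` gives 1000 nM. Among the measured compounds shown here, the only one-place step known is a 10-fold higher number from compound 1 to compound 3 (1.00 log units; beyond the scatter). Compound 4 `O=C(O)c1ccc(C(=O)/C(=C\c2ccc(Br)c([N+](=O)[O-])c2)SCc2ccc(F)cc2)cc1` differs from compound 3 by 4-bromo-3-nitrophenyl in place of 3-hydroxy-4-methoxyphenyl on a double-bonded chain carbon bound to a double-bonded chain carbon. This change puts back a halogenated nitrophenyl of the kind carried by compound 1 and compound 2, and compound 2 with the same 4-bromo-3-nitrophenyl shows the same number as compound 1. The step from compound 1 to compound 3 is therefore expected to be reversed: a lower number for compound 4, estimated as a 10-fold lower number from compound 3 to compound 4 (1.00 log units; beyond the scatter). Compound 4 is expected at 1000 nM, within 400 nM to 3000 nM.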

Compound 4, concentration for 50% growth inhibition: 1000 nM
For compound 4 middle estimate and measured number coincide at the digits printed, and the stated range covers the measured number.
By their numbers in this assay, from the lowest: compounds 1, 2 and 4 (each within the scatter of the next); then compound 3.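

In this assay, 4-bromo-3-nitrophenyl in place of 3-hydroxy-4-methoxyphenyl on a double-bonded chain carbon bound to a double-bonded chain carbon gives a 10-fold lower number from compound 3 to compound 4 (1.00 log units; beyond the scatter), so the gain in growth inhibition is not confined to the 4-fluoro-3-nitrophenyl group. At this position, bromo in place of fluoro gives no change at the digits printed from compound 1 to compound 4 (within the scatter). At the other halogen-bearing aromatic carbon, fluoro in place of bromo gives no change at the digits printed from compound 2 to compound 4 (within the scatter).

Going by these compounds, each aryl exchange alters several substituents at once, so what a nitrophenyl with an amine or a nitrile in place of the nitro group would give stays open. No measurement shown explains these numbers.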